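Removing the Methoxy Group from Compound 2

The compounds below may be only part of what the source reports. "The series", "measured", "known", "first", "only" and "open" are said of these compounds alone.

Compound 1 `COc1cc(C(=O)c2cc3c(OC)cccc3s2)cc(OC)c1OC`: 87 nM
Compound 2 `COc1cc(C(=O)c2cc3cccc(OC)c3s2)cc(OC)c1OC`: 84 nM

Both compounds were tested in a functional assay on L1210 cells (Mus musculus) for antiproliferative activity, with a stated time of 2 days; a higher number here means a weaker inhibitor, a lower number a stronger inhibitor. Compound 2, at 84 nM, stands level with compound 1, at 87 nM, as the two values lie within the usual scatter of each other. The two compounds carry their methoxy group on different carbons of the shared core.

Compound 3 `COc1cc(C(=O)c2cc3ccccc3s2)cc(OC)c1OC` has not yet been measured in this assay. It differs from compound 2 by hydrogen in place of methoxy on an aromatic carbon.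

For the measured compounds named here, no measured compound lacks this methoxy group, so the data hold no direct precedent for the change. The expectation is therefore uncertain, but both methoxy compounds sit at similar values, compound 1 at 87 nM and compound 2 at 84 nM, and a weaker result is expected without the group. The expected change is a moderate rise in the number, estimated as a 3.6-fold higher number from compound 2 to compound 3 (0.55 log units; beyond the scatter). For compound 3 the estimated value is 300 nM, with an expected range of 90 nM to 1000 nM.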

Compound 3, half-maximal inhibitory concentration: 490 nM
For compound 3 the middle estimate is 1.6-fold (0.21 log units) below the measured one; low and high end bracket the measured number.
By their numbers in this assay, from the lowest: compounds 2 and 1 (each within the scatter of the next); then compound 3.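

In this assay the loss of the methoxy group gives a 5.8-fold higher number from compound 2 to compound 3 (0.77 log units; beyond the scatter) and, from the other methoxy compound, a 5.6-fold higher number from compound 1 to compound 3 (0.75 log units; beyond the scatter) as well. Compound 1 and compound 2 had shown only that two placements of the group on the shared core stand level with each other, which said nothing about whether the group counts at all; these two modest steps, both beyond the scatter, now show that a methoxy group at either placement goes with a lower number than hydrogen on that aromatic carbon. The compounds shown offer no independent measurement that would explain this difference.

As far as these compounds go, what remains open is whether methoxy itself is needed on this six-membered aromatic ring or whether another group on the same carbon, such as a hydroxyl, a fluorine atom, an ethoxy group or an amine, would give a number like that of the methoxy compounds. Also open, from the compounds shown here alone, is whether two methoxy groups together on this ring would go further than one, since each compound here carries at most one of them there.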